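Urea to Amide to Piperidinyl Urea on a Shared Core

This account rests on a few compounds, and the source may have more. Where it says the series, first, only, none or still open, it means among the compounds named here.

Within the data shown here, compound 2 `O=C(CC1CCCCCC1)N1CCC(c2nc(-c3ccc4ccccc4n3)no2)CC1` carries the highest of the two numbers known so far: in a functional assay on Shh Light II cells (Mus musculus) for inhibition, read by a luciferase reporter (a higher number here means a weaker inhibitor, a lower number a stronger inhibitor), compound 2 gives 840 nM, while its nearest neighbour, compound 1 `O=C(Nc1ccccc1Cl)N1CCC(c2nc(-c3ccc4ccccc4n3)no2)CC1`, gives 510 nM in this assay. Compound 3 `O=C(NC1CCNCC1)N1CCC(c2nc(-c3ccc4ccccc4n3)no2)CC1` differs from compound 2 by (piperidin-4-yl)amino in place of cycloheptylmethyl on a carbonyl carbon. Among the measured compounds shown here, the only measured step touching this carbonyl substituent is a 1.6-fold higher number from compound 1 to compound 2 (0.22 log units; within the scatter), which stayed within the scatter, and no measured compound carries the entering group. Compound 3 is therefore expected to stay close, estimated at 1000 nM with a range from 250 nM to 4000 nM, which would be a step of a 1.2-fold higher number from compound 2 to compound 3 (0.08 log units; within the scatter) and need not exceed the scatter.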

Compound 3, half-maximal inhibitory concentration: 2500 nM
The estimate for compound 3 lay 2.5-fold (0.40 log units) below the measured number, and the stated range covers the measured number.
By their numbers in this assay, from the lowest: compounds 1 and 2 (each within the scatter of the next); then compound 3.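

Placing (piperidin-4-yl)amino on the carbonyl carbon gives a 3.0-fold higher number from compound 2 to compound 3 (0.47 log units; beyond the scatter) in this assay, and piperidin-4-yl in place of 2-chlorophenyl on the amide-type nitrogen gives a 4.9-fold higher number from compound 1 to compound 3 (0.69 log units; beyond the scatter). Compounds 1 and 2 had stayed within the scatter of each other, so only now does this position show a change beyond it, with both steps running towards a weaker inhibitor. No evidence is available that accounts for this shift.

The compounds shown leave open how a cyclohexyl group on the same amide-type nitrogen would read. They also leave open whether an open-chain amine or a carboxylic acid on the carbonyl carbon would sit with compound 3 or with compounds 1 and 2.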